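Notes on a five-membered to six-membered ring swap

The source may hold more compounds than are shown below. What is called first, only, known or untested is meant among the compounds shown, and "the series" means these compounds.

The three measured compounds share one core carrying a 3-hydroxyphenyl group, a second hydroxyphenyl group and a third aromatic ring. Compound 1 `Oc1ccc(-c2cc(-c3ccco3)cc(-c3cccc(O)c3)n2)cc1` gives 5170 nM in a functional assay on HeLa cells (Homo sapiens) for cytotoxicity, read by CCK-8 assay; a higher number here means a weaker inhibitor, a lower number a stronger inhibitor. Compound 2 `Oc1cccc(-c2cc(-c3ccoc3)cc(-c3cccc(O)c3)n2)c1` gives 4630 nM in this assay, and compound 3 `Oc1ccc(-c2cc(-c3ccoc3)cc(-c3cccc(O)c3)n2)cc1` gives 3310 nM in this assay. Compound 3 holds the lowest of the three numbers, but the step of a 1.6-fold lower number from compound 1 to compound 3 (0.19 log units; within the scatter) and the step of a 1.4-fold lower number from compound 2 to compound 3 (0.15 log units; within the scatter) are both within the scatter, so no order among the three is established.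

Compound 4 `Oc1ccc(-c2cc(-c3ccccn3)cc(-c3cccc(O)c3)n2)cc1` differs from compound 3 in one place: pyridin-2-yl in place of furan-3-yl on an aromatic carbon. Within the data shown here, the only measured step at that place, a 1.6-fold lower number from compound 1 to compound 3 (0.19 log units; within the scatter), exchanged one five-membered ring for another and stayed within the scatter; the step of a 1.4-fold lower number from compound 2 to compound 3 (0.15 log units; within the scatter) concerns a different place and bears only loosely. Among the measured compounds shown here, no measured compound carries a six-membered ring there, so the ring size is untested. The step of a 1.1-fold higher number from compound 3 to compound 4 (0.02 log units; within the scatter) is therefore expected to remain within the scatter. Compound 4 is estimated at 3500 nM in this assay, with a range of 1200 nM to 9500 nM widened for the untested ring.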

Compound 4, half-maximal inhibitory concentration: 1930 nM
Estimate against measurement, compound 4: 1.8-fold (0.26 log units) above; the measured number falls inside the stated range.
By their numbers in this assay, from the lowest: compounds 4, 3, 2 and 1 (each within the scatter of the next, the first and the last beyond it).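

The six-membered pyridin-2-yl ring is accepted at this place, opposite the ring nitrogen: in this assay the step of a 1.7-fold lower number from compound 3 to compound 4 (0.23 log units; within the scatter) stays within the scatter, so a larger ring shows no separable effect against furan-3-yl. Against furan-2-yl, the step of a 2.7-fold lower number from compound 1 to compound 4 (0.43 log units; beyond the scatter) is modest but is the first in the series beyond the scatter, so a change at this place can move the number measurably. No evidence bears on why the number moves at this place.

Open, from the compounds shown here alone, is how a plain phenyl ring, a pyridin-4-yl ring or an aliphatic amine would read at this place, and so whether the ring nitrogen or the ring size matters more. Also open, going by these compounds, is whether pyridin-2-yl gives a similar number when paired with the two 3-hydroxyphenyl groups of compound 2.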